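Replacing fluoro with methoxy in compound 1

The compounds below may be only part of what the source reports. "The series", "measured", "known", "first", "only" and "open" are said of these compounds alone.

In an ADME assay on HaCaT cells (Homo sapiens) for antiproliferative activity, read by MTT assay, with a stated time of 48 h (a lower number here means a stronger inhibitor, a higher number a weaker inhibitor), compound 1 (`O=C(/C=C\Nc1ccc(Cl)cc1)c1cn(-c2ccccc2)nc1-c1ccc(F)cc1`) gives 21300 nM, within the scatter of compound 3 (`O=C(/C=C\Nc1ccc(O)cc1)c1cn(-c2ccccc2)nc1-c1ccc(F)cc1`) at 16300 nM. Compound 2 (`O=C(/C=C\Nc1ccc(C(F)(F)F)cc1)c1cn(-c2ccccc2)nc1-c1ccc(F)cc1`) reads > 50000 nM, which is a limit of the assay. Compound 4 (`COc1ccc(-c2nn(-c3ccccc3)cc2C(=O)/C=C\Nc2ccc(Cl)cc2)cc1`) keeps the core of compound 1 but turns the 4-fluorophenyl into 4-methoxyphenyl: methoxy in place of fluoro on an aromatic carbon. Going by the values given here, no measured step touches this place. Among the compounds with values here, the only guides are swaps of the chloro group elsewhere in the molecule: hydroxy gave a 1.3-fold lower number from compound 1 to compound 3 (0.12 log units; within the scatter), and trifluoromethyl gave an at least 2.3-fold higher number from compound 1 to compound 2 (0.37 log units; beyond the scatter). These are loose guides, so in this assay no step beyond the scatter is expected, and neither direction is favoured. The estimated step is a 1.0-fold higher number from compound 1 to compound 4 (0.01 log units; within the scatter). For compound 4, the estimate is 22000 nM, with an expected range of 9000 nM to 50000 nM.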

Compound 4, half-maximal inhibitory concentration: 20900 nM
Compound 4: the middle estimate sits 1.1-fold (0.02 log units) above what was measured, and the stated range covers the measured number.
By their numbers in this assay, from the lowest: compounds 3, 4 and 1 (each within the scatter of the next). At a limit, above all of these: compound 2.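

In this assay, going by these compounds alone, turning 4-fluorophenyl into 4-methoxyphenyl gives a 1.0-fold lower number from compound 1 to compound 4 (0.01 log units; within the scatter), so the first change at this place, which the earlier compounds left untouched, produces no readable shift. Methoxy brings a hydrogen-bond acceptor that fluoro lacks, yet the number stays within the scatter. Nothing measured here offers an explanation for this result. As far as these compounds go, whether an amine, a carboxylic acid or a longer chain at this place would shift the number remains open. So does whether methoxy would behave the same alongside the hydroxy of compound 3.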